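The source may report more compounds than this note shows. Statements on the series, on what has been measured and on what is new or still open speak of the compounds shown alone.

Three compounds of a shared core have been run in an in vitro ADME assay on microsomes from liver (Homo sapiens) for metabolic stability; on this read-out higher numbers stand for fast clearance and lower numbers for slow clearance. Compound 1 `Cc1oc(-c2ccccc2)nc1CN1CCCC(C(=O)NCC2CCOCC2)C1` gives 105 mL.min-1.g-1. Compound 2 `Cc1cccc(CNC(=O)[C@H]2C[C@H](c3nc(C)no3)CN(Cc3nc(-c4ccccc4)oc3C)C2)n1` gives 290 mL.min-1.g-1. Compound 3 `Cc1oc(-c2ccccc2)nc1CN1CCC[C@@H](C(=O)NC[C@@H]2CCCO2)C1` gives 69.1 mL.min-1.g-1, the lowest of the three numbers, though its gap to compound 1 lies within the usual scatter of the assay and only its gap to compound 2 lies beyond it. So compound 3 is cleared clearly more slowly than compound 2, while against compound 1 no real difference can be claimed.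

The step from compound 3 to compound 4 `Cc1oc(-c2ccccc2)nc1CN1CCC[C@@H](C(=O)NCc2cccc(N)n2)C1` changes one place in the amide side chain: 6-aminopyridin-2-yl in place of oxolan-2-yl on a saturated chain carbon bound to an amide-type nitrogen. A saturated ring with one oxygen is thus exchanged for an aromatic ring carrying an amino group, on the carbon that is bound to the amide-type nitrogen.

Within the data shown here, no measured pair in this set isolates that exchange, so the direction of the step is open. Among the measured compounds shown here, compound 2, the only other compound with an aromatic ring at that position, carries a high number, but it differs in a second place too, and only its own value can be read from it. The step of a 1.4-fold higher number from compound 3 to compound 4 (0.16 log units; within the scatter) is expected to be small, at most a modest rise. For compound 4 the estimate is 100 mL.min-1.g-1, with a range from 45 mL.min-1.g-1 to 220 mL.min-1.g-1.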

Compound 4, intrinsic clearance in microsomes: 49 mL.min-1.g-1
Beside the measured number, compound 4's estimate is 2.0-fold (0.31 log units) above it, within the range that was stated.
By their numbers in this assay, from the lowest: compounds 4, 3 and 1 (each within the scatter of the next, the first and the last beyond it); then compound 2.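

In this assay, the exchange of oxolan-2-yl for 6-aminopyridin-2-yl on a saturated chain carbon bound to an amide-type nitrogen gives a 1.4-fold lower number from compound 3 to compound 4 (0.15 log units; within the scatter). Among these compounds, this is the first pair in the set that differs in one place, and it shows that a saturated ring with one oxygen and an aromatic ring carrying an amino group cannot be told apart at this position on this read-out, so an aromatic ring here does not by itself go with a high number. Nothing measured here offers an explanation for this result.

As far as these compounds go, whether the amino group itself counts remains open, as a pyridin-2-yl group without it, or a plain phenyl ring, could read differently at this place. Also open, from the compounds shown here alone, is whether a longer chain between the amide nitrogen and the ring, or a carboxylic acid in place of the amino group, would move the number beyond the scatter, and whether the same exchange would read alike on the core of compound 2.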